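Changing a fluoro to methoxy on a shared thiazolidinone core

The source may report more compounds than this note shows. Statements on the series, on what has been measured and on what is new or still open speak of the compounds shown alone.

Four compounds share one core and differ only in the group carried on an outer benzene ring. Compound 1 is `CN1CCN(c2nc(Oc3ccc(C#N)cc3)nc(-c3ccc(N4C(=O)CSC4c4ccc(Cl)cc4)cc3)n2)CC1`, compound 2 is `CN1CCN(c2nc(Oc3ccc(C#N)cc3)nc(-c3ccc(N4C(=O)CSC4c4ccc(Br)cc4)cc3)n2)CC1`, compound 3 is `CN1CCN(c2nc(Oc3ccc(C#N)cc3)nc(-c3ccc(N4C(=O)CSC4c4ccc(F)cc4)cc3)n2)CC1` and the still unmeasured compound 4 is `COc1ccc(C2SCC(=O)N2c2ccc(-c3nc(Oc4ccc(C#N)cc4)nc(N4CCN(C)CC4)n3)cc2)cc1`. All are tested in an ADME assay on Vero cells (Chlorocebus sabaeus) for cytotoxicity, read by MTT assay, with a stated time of 72 h; on this read-out higher numbers stand for weaker inhibition and lower numbers for stronger inhibition. For compound 1 the entry reads "not determined" (no result reported). For compound 3 the entry likewise reads "not determined" (no result reported), so compound 3 stands without any number of its own. Compound 2 reaches only a limit of this assay at > 62.5 ug/mL. Among the three entries, then, one is the limit of > 62.5 ug/mL in this assay, at which 1 of the 3 values shown sits, and two carry no number at all. The move from compound 3 to compound 4 is methoxy in place of fluoro on an aromatic carbon. For the measured compounds named here, with no measured step to lean on, the step in this assay is expected to stay within the usual scatter, in no particular direction. Compound 4 is therefore estimated at 62.5 ug/mL, with a range from 30 ug/mL to 120 ug/mL, and a limit rather than a number is the likelier outcome.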

Compound 4, half-maximal inhibitory concentration: > 62.5 ug/mL
Compound 4: no number, only a limit (the forecaster's own chance of this, stated with the estimate: 70%); the middle value lies on the limit itself.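

No new step can be read in this assay: compound 2 and compound 4 each give only a limit, while compound 1 and compound 3 have no reported result. Going by these compounds, whether the group on the outer benzene ring affects cytotoxicity in this assay remains open.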